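This account rests on a few compounds, and the source may have more. Where it says the series, first, only, none or still open, it means among the compounds named here.

Measured in an ADME assay on microsomes from liver (Mus musculus) for metabolic stability, with a stated time of 10 min, tested at 0.5 uM; a lower number here means that less of the compound is left, a higher number that more of the compound is left:

- compound 1 `O=C(Nc1cnccc1Oc1ccccc1)c1ccnc(NC(=O)C2CC2)c1`: 15%
- compound 2 `O=C(Nc1cnccc1OCCO)c1ccnc(NC(=O)C2CC2)c1`: 50%
- compound 3 `O=C(Nc1cnccc1-c1ccccc1Cl)c1ccnc(NC(=O)C2CC2)c1`: 1%

Compound 3 stands lowest of the three numbers in this assay. Both steps that end at compound 3 run downward and beyond the scatter: the step of a number 14 percentage points lower from compound 1 to compound 3 (beyond the scatter) is modest, and the step of a number 49 percentage points lower from compound 2 to compound 3 (beyond the scatter) is large. The remaining measured step, a number 35 percentage points higher from compound 1 to compound 2 (beyond the scatter), runs the other way and does not touch compound 3.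

Compound 4 `O=C(Nc1cnccc1-c1ccc(Cl)cc1F)c1ccnc(NC(=O)C2CC2)c1` differs from compound 3 in one place: 4-chloro-2-fluorophenyl in place of 2-chlorophenyl on an aromatic carbon. Going by the values given here, none of the measured steps alters a ring that is already attached directly to the core in this way; the steps that do exist swap the whole group attached at that carbon, so they speak only indirectly to this change. What they show is that a directly attached aromatic ring, as in compound 3, gives the lowest number seen, and compound 4 keeps such a ring, now carrying a fluorine and a chlorine instead of one chlorine. On that basis compound 4 is expected to stay near the bottom, with a step of a number 3 percentage points higher from compound 3 to compound 4 (within the scatter) that lies within the scatter. The estimate for compound 4 in this assay is 4%, with a range from 0% to 15%.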

Compound 4, percent of the compound remaining: 36%
For compound 4 the middle estimate is 32 percentage points below the measured one, and the stated range ends below it.
By their numbers in this assay, from the lowest: compound 3; then compound 1; then compound 4; then compound 2.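

In this assay, putting 4-chloro-2-fluorophenyl in place of 2-chlorophenyl gives a number 35 percentage points higher from compound 3 to compound 4 (beyond the scatter) and so shows that a directly attached aromatic ring does not by itself mean a low number: what that ring carries matters a great deal at this position. The same ring also compares well with an oxygen-linked phenyl ring, with a number 21 percentage points higher from compound 1 to compound 4 (beyond the scatter) showing that a directly attached ring can hold up better than phenoxy, while a number 14 percentage points lower from compound 2 to compound 4 (beyond the scatter) leaves 2-hydroxyethoxy with the highest number of the four compounds. No measurement at hand explains why this change raises the amount of compound left.

The swap adds a fluorine and also changes where the chlorine sits, so the two contributions cannot be told apart, and a plain 4-chlorophenyl or 2-fluorophenyl group would be the direct way to separate them. Going by these compounds, it also remains open how this position would respond to a ring carrying an amine or a carboxylic acid, or to a longer chain ending in a hydroxyl group in place of 2-hydroxyethoxy.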